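A few compounds are considered here, and "the series" means these few. Any claim that something is new, unique, unknown or untested is made for them only; others in the source may bear on it.

Compound 1 `COc1ccc(-c2c[nH]c(=O)n2-c2cc(OC)c(OC)c(OC)c2)cc1OC`: "not determined" (no result reported)
Compound 2 `COc1ccc(-c2c[nH]c(=O)n2-c2cc(OC)c(OC)c(OC)c2)cc1[N+](=O)[O-]`: "not determined" (no result reported)
Compound 3 `COc1ccc(-c2c[nH]c(=O)n2-c2cc(OC)c(OC)c(OC)c2)cc1N`: > 50000 nM

Three compounds share the core of compound 2 in a functional assay on MCF7 cells (Homo sapiens) for cytotoxicity, read by MTT assay, with a stated time of 48 h; a higher number here means a weaker inhibitor, a lower number a stronger inhibitor. Compound 1 and compound 2 carry no result in this assay. For compound 3 the entry in this assay is a limit of the assay, not a number, (the limit of > 50000 nM in this assay, at which 1 of the 3 values shown sits). Compound 2 therefore stands without a number, with only one limit and one empty entry beside it. The step to compound 4 `COc1ccc(-c2cn(C(C)=O)c(=O)n2-c2cc(OC)c(OC)c(OC)c2)cc1[N+](=O)[O-]` is acetyl in place of hydrogen on an aromatic nitrogen. Among the compounds with values here, with no measured step in this assay to lean on, nothing beyond the usual scatter is expected in either direction, and the weak showing of compound 3 at > 50000 nM is the only anchor. Compound 4 is expected to give about 30000 nM in this assay, between 8000 nM and 60000 nM.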

Compound 4, half-maximal inhibitory concentration: > 50000 nM
Compound 4: only a limit was reported; the forecaster's own chance of this, stated with the estimate: 45%; middle value at least 1.6-fold (0.22 log units) away from the limit.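

Compound 4 gives > 50000 nM, a limit and not a number. With no single number for compound 2, no step can be read from it to compound 4. The compounds shown leave open how acetyl in place of hydrogen on the aromatic nitrogen shifts the value in this assay.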